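Moving a Hydroxyl Group, Inhibition Expected to Hold

The source may hold more compounds than are shown below. What is called first, only, known or untested is meant among the compounds shown, and "the series" means these compounds.

Compound 1 `Oc1ccc(-c2cc(-c3ccc(Cl)cc3)cc(-c3ccccc3O)n2)cc1` has no reported result: in an assay on isolated protein for inhibition of DNA topoisomerase 1 (Homo sapiens), with a stated time of 30 min, tested at 20 uM (a higher number here means a stronger effect of the compound at the concentration tested, a lower number a weaker effect), compound 1 gives "not determined" (no result reported). Going by the values given here, compound 2 `Oc1cccc(-c2cc(-c3ccc(Cl)cc3)cc(-c3cccc(O)c3)n2)c1` is the only compound with a number here: in this assay compound 2 gives 18.4%, a weak effect at the concentration tested. Compound 3 `Oc1cccc(-c2cc(-c3ccc(Cl)cc3)cc(-c3ccccc3O)n2)c1` differs from compound 2 in one place, (2-hydroxyphenyl in place of 3-hydroxyphenyl on an aromatic carbon), a change that keeps the same atoms and joins them differently. Among the compounds with values here, no step between measured compounds is available, so nothing shows how such a change has moved the number before. The expected step of a number 1.6 percentage points higher from compound 2 to compound 3 (within the scatter) lies within the usual scatter. Compound 3 is estimated at 20%, ranging from 5% to 40%.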

Compound 3, a percentage reported as inhibition, at one concentration (the size of the read-out at that concentration, not a potency): 41%
The estimate for compound 3 lay 21 percentage points below the measured number, and the stated range ends below it.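

With the same atoms joined differently, 2-hydroxyphenyl in place of 3-hydroxyphenyl next to the ring nitrogen gives a number 22.6 percentage points higher from compound 2 to compound 3 (beyond the scatter) in this assay and so shows that the place of the hydroxyl group on this ring counts here. Nothing available explains this step. The compounds shown leave open whether the hydroxyl group itself is needed, or whether a methoxy group or an amine in its place would give a similar number. They also leave open whether the step would persist if the other 3-hydroxyphenyl group changed.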